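A few compounds are considered here, and "the series" means these few. Any claim that something is new, unique, unknown or untested is made for them only; others in the source may bear on it.

Measured in an ADME assay on BEAS-2B cells (Homo sapiens) for cytotoxicity, read by MTT assay, with a stated time of 72 h; on this read-out lower numbers stand for stronger inhibition and higher numbers for weaker inhibition:
- compound 1 `O=C(Nc1cc(Nc2ccc(Cl)cc2)ncn1)c1ccc(F)cc1`: 18600 nM
- compound 2 `CCOc1ccc(Nc2cc(NC(=O)c3ccccc3)ncn2)cc1`: 17400 nM

For the measured compounds named here, these two values lie within the scatter of each other, so compound 1 stands level with compound 2 on the numbers so far. Compound 3 `O=C(O)CCC(=O)Nc1cc(Nc2ccc(Cl)cc2)ncn1` keeps the core of compound 1 and carries 2-carboxyethyl in place of 4-fluorophenyl on a carbonyl carbon. Going by the values given here, no measured pair isolates a change like this one, so the expectation is loose. A moderate move toward a higher number, meaning weaker inhibition, is expected, with the estimated step of a 2.2-fold higher number from compound 1 to compound 3 (0.33 log units; beyond the scatter). Compound 3 is estimated at 40000 nM, with a range of 15000 nM to 110000 nM.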

Compound 3, half-maximal inhibitory concentration: 19000 nM
For compound 3 the middle estimate is 2.1-fold (0.32 log units) above the measured one; low and high end bracket the measured number.
By their numbers in this assay, from the lowest: compounds 2, 1 and 3 (each within the scatter of the next).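

In this assay, 2-carboxyethyl in place of 4-fluorophenyl on a carbonyl carbon gives a 1.0-fold higher number from compound 1 to compound 3 (0.01 log units; within the scatter). For the compounds shown here, this is the first measured change at this position, and it shows that an open chain with no ring and a six-membered aromatic ring of carbon only can read alike here, at least on the core of compound 1. Nothing available accounts for this parity. Open, on these data alone, is whether an aminoethyl chain, a longer chain or the methyl ester of 2-carboxyethyl on this carbonyl carbon would also read alike.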